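A Change of Acyl Group on the Shared Core

The source may hold more compounds than are shown below. What is called first, only, known or untested is meant among the compounds shown, and "the series" means these compounds.

Compound 1 `O=C(NCc1ccc(CNS(=O)(=O)c2ccc3c(c2)CCO3)cc1)c1cccc2c1COC2` gives 1000 nM in an assay on cells for displacement of a labelled ligand from C-X-C chemokine receptor type 4 (Homo sapiens), read by fluorescence and microscopy, with stated times of 10 min and 30 min; a lower number here means that less compound is needed, a higher number that more compound is needed for the effect.
Compound 2 `O=C(NCc1ccc(CNS(=O)(=O)c2ccccc2F)cc1)c1cc2ccccn2n1` gives 100 nM in this assay.
Compound 3 `Cc1cc(C(=O)NCc2ccc(CNS(=O)(=O)c3ccc4c(c3)CCO4)cc2)n(C)n1` gives 1000 nM in this assay.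

Compound 3 stands level with compound 1, the two together the highest of the three numbers, while compound 2 lies well below both, beyond the scatter. Compound 4 `O=C(NCc1ccc(CNS(=O)(=O)c2ccc3c(c2)CCO3)cc1)c1cc2ccccn2n1` carries a group of 9 heavy atoms (7 carbon, 2 nitrogen; one five-membered aromatic ring with 2 hetero atoms, one six-membered aromatic ring with 1 hetero atom) in place of a group of 7 heavy atoms (5 carbon, 2 nitrogen; one five-membered aromatic ring with 2 hetero atoms), on a carbonyl carbon. Going by the values given here, the one measured step at the same place, no change at the digits printed from compound 1 to compound 3 (within the scatter), showed no change. Compound 2 shares the entering group with compound 4 but differs from compound 3 in a second place as well, so its value only hints at a lower number. Compound 4 is therefore expected to give a modest lowering, a 3.3-fold lower number from compound 3 to compound 4 (0.52 log units; beyond the scatter). The estimate for compound 4 is 300 nM, within 100 nM to 1000 nM.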

Compound 4, effective concentration (reported as EC, without a stated level of effect): 1 nM
Compound 4: the middle estimate sits 300-fold (2.48 log units) above what was measured; measured number outside the range, below it.
By their numbers in this assay, from the lowest: compound 4; then compound 2; then compounds 1 and 3 (each within the scatter of the next).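

On a carbonyl carbon, the acyl group proves decisive in this assay: the entering group, with its five-membered and six-membered aromatic rings, gives a 1000-fold lower number from compound 3 to compound 4 (3.00 log units; beyond the scatter) and a 1000-fold lower number from compound 1 to compound 4 (3.00 log units; beyond the scatter), although the earlier step at this place had shown no change. The sulfonyl sulfur also proves sensitive with this acyl group in place, with a 100-fold lower number from compound 2 to compound 4 (2.00 log units; beyond the scatter) when the oxygen-containing group replaces the fluorine-containing one. No evidence is available that bears on these large steps. Still open, as far as these compounds go, is whether both rings of the entering group are needed, which a phenyl or pyridyl group on the carbonyl carbon would test.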